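From methyl to 5-bromothiophen-2-yl on the sulfonyl sulfur

The compounds below may be only part of what the source reports. "The series", "measured", "known", "first", "only" and "open" are said of these compounds alone.

In a functional assay on HepG2 cells (Homo sapiens) for inhibition, read by sulforhodamine B assay, with a stated time of 74 h (on this read-out lower numbers stand for stronger inhibition and higher numbers for weaker inhibition), compound 1 (`CS(=O)(=O)N1C(=O)COC12C=CC(=O)C=C2`) gives > 10000 nM, which is a limit and not a number. Compound 2 (`O=C1C=CC2(C=C1)OCC(=O)N2S(=O)(=O)c1ccc([N+](=O)[O-])cc1`) gives > 10000 nM, also a limit. Compound 3 (`CC1OC2(C=CC(=O)C=C2)N(S(=O)(=O)c2cccs2)C1=O`) gives > 10000 nM, again a limit. Among the compounds with values here, the series so far sits at the limit of > 10000 nM in this assay, at which 3 of the 3 values shown sit, so compound 1 has no number to stand on and no measured step is available as a guide.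

Compound 4 (`O=C1C=CC2(C=C1)OCC(=O)N2S(=O)(=O)c1ccc(Br)s1`) differs from compound 1 in one place: 5-bromothiophen-2-yl in place of methyl on a sulfonyl sulfur. Compound 3 at > 10000 nM already carries a five-membered aromatic ring with 1 hetero atom on its sulfonyl sulfur, so a large gain in this assay is not expected. A modest move toward stronger inhibition is the most that is expected, and another limit would be no surprise. The expected step is an at least 1.4-fold lower number from compound 1 to compound 4 (0.15 log units; that floor lies within the scatter). For compound 4 the estimated value is 7000 nM, with an expected range of 1500 nM to 25000 nM.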

Compound 4, half-maximal inhibitory concentration: 240 nM
Estimate against measurement, compound 4: 29-fold (1.46 log units) above; measured number outside the range, below it.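

The sulfonyl sulfur turns out to be a position that can move this series: in this assay, replacing methyl with 5-bromothiophen-2-yl gives an at least 41-fold lower number from compound 1 to compound 4 (1.61 log units; beyond the scatter). The earlier compounds shown here showed only limits, so they gave no sign that a change at this position on the shared core could produce a measurable value. Compound 4 is the only compound shown with a number rather than a limit: the limit of > 10000 nM in this assay, at which 3 of the 4 values shown sit.

Compound 3 differs from compound 4 in more than one place, so the bromine and the thiophene ring cannot be separated as contributors to the step. As far as these compounds go, the result for a plain thiophen-2-yl or 5-chlorothiophen-2-yl group on the unchanged core of compound 4 remains open, as does the effect of a phenyl group carrying a bromine.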